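Replacing piperidin-1-yl on the side chain of compound 1

The compounds below may be only part of what the source reports. "The series", "measured", "known", "first", "only" and "open" are said of these compounds alone.

Compound 1 `CC(C)=CCc1cc(C(=O)Nc2cc3ccc(OCCCN4CCCCC4)c(C)c3oc2=O)ccc1O` was tested in a functional assay on MCF7 cells (Homo sapiens) for antiproliferative activity; a lower number here means a stronger inhibitor, a higher number a weaker inhibitor. For compound 1 the result is only a limit of the assay, > 50000 nM, and not a number. Two close relatives differ from compound 1 only on a saturated chain carbon, three bonds along the chain from an oxygen on an aromatic ring. Compound 2 `CCNCCCOc1ccc2cc(NC(=O)c3ccc(O)c(CC=C(C)C)c3)c(=O)oc2c1C` gives 980 nM in this assay, and compound 3 `CC(C)=CCc1cc(C(=O)Nc2cc3ccc(OCCCN(C)C(C)C)c(C)c3oc2=O)ccc1O` gives 1050 nM. Both steps away from compound 1 are large: an at least 51-fold lower number from compound 1 to compound 2 (1.70 log units; beyond the scatter) and an at least 47-fold lower number from compound 1 to compound 3 (1.67 log units; beyond the scatter). Between the two relatives there is no real difference, a 1.1-fold higher number from compound 2 to compound 3 (0.03 log units; within the scatter).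

Compound 4 `CC(C)=CCc1cc(C(=O)Nc2cc3ccc(OCCCN[C@H](C)c4ccccc4)c(C)c3oc2=O)ccc1O` has not yet been measured. It differs from compound 1 at the same place as compounds 2 and 3 do: (1-phenylethyl)amino in place of piperidin-1-yl on a saturated chain carbon, three bonds along the chain from an oxygen on an aromatic ring. Given that the steps of an at least 51-fold lower number from compound 1 to compound 2 (1.70 log units; beyond the scatter) and an at least 47-fold lower number from compound 1 to compound 3 (1.67 log units; beyond the scatter) were both large, a step of similar size and direction is expected for compound 4: an at least 50-fold lower number from compound 1 to compound 4 (1.69 log units; beyond the scatter). The estimate for compound 4 in this assay is 1000 nM, with a likely range from 300 nM to 4000 nM.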

Compound 4, half-maximal inhibitory concentration: 1450 nM
The estimate for compound 4 lay 1.5-fold (0.16 log units) below the measured number; the measured number falls inside the stated range.
By their numbers in this assay, from the lowest: compounds 2, 3 and 4 (each within the scatter of the next). At a limit, above all of these: compound 1.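

In this assay, moving away from piperidin-1-yl again gives a large step, this time with (1-phenylethyl)amino, which brings in a six-membered aromatic ring of carbon only and a defined stereocentre: an at least 34-fold lower number from compound 1 to compound 4 (1.53 log units; beyond the scatter). That group cannot be told apart from the two smaller amines, with a 1.4-fold higher number from compound 3 to compound 4 (0.14 log units; within the scatter) and a 1.5-fold higher number from compound 2 to compound 4 (0.17 log units; within the scatter), so among these three compounds, phenyl in place of hydrogen on the chain carbon bound to the amine nitrogen leaves no readable difference. Compound 1 remains a limit of the assay and not a number, so each step from it gives only a minimum size: the limit of > 50000 nM in this assay, at which 1 of the 4 values shown sits.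

The compounds shown leave open whether the loss belongs to piperidin-1-yl alone or to ring amines in general, a question that a pyrrolidin-1-yl or morpholin-4-yl group on the same chain would address. Also open, going by these compounds, are what the defined stereocentre of compound 4 contributes, which its mirror-image form would show, and how a shorter or longer chain carrying the same amines would behave.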